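The compounds below may be only part of what the source reports. "The series", "measured", "known", "first", "only" and "open" are said of these compounds alone.

In a functional assay on HCT-116 cells (Homo sapiens) for antiproliferative activity (on this read-out higher numbers stand for weaker inhibition and lower numbers for stronger inhibition), compound 1 (`CC(=O)N1CCc2c(C)c3c(n2-c2ccc(C(N)=O)c(c2)N[C@@H](C)[C@H](C)C1)CC(C)(C)CC3=O`) gives 24 nM and compound 2 (`COCCC(=O)N1CCc2c(C)c3c(n2-c2ccc(C(N)=O)c(c2)N[C@@H](C)[C@H](C)C1)CC(C)(C)CC3=O`) gives 38 nM with a step between them (a 1.6-fold higher number from compound 1 to compound 2 (0.20 log units; within the scatter)) that does not separate the two. Compound 3 (`Cc1c2c(n3c1CCN(C(=O)C1(N)CC1)C[C@@H](C)[C@H](C)Nc1cc-3ccc1C(N)=O)CC(C)(C)CC2=O`) stands highest of the three at 81 nM and is the weakest inhibitor measured so far. Its 1-aminocyclopropyl on the carbonyl carbon replaces methyl in one modest step (a 3.4-fold higher number from compound 1 to compound 3 (0.53 log units; beyond the scatter)) and 2-methoxyethyl in another (a 2.1-fold higher number from compound 2 to compound 3 (0.33 log units; beyond the scatter)). Compound 4 (`Cc1c2c(n3c1CCN(C(=O)C1(N)CCCC1)C[C@@H](C)[C@H](C)Nc1cc-3ccc1C(N)=O)CC(C)(C)CC2=O`) carries 1-aminocyclopentyl in place of 1-aminocyclopropyl on a carbonyl carbon. Within the data shown here, no measured step makes this exchange, so those two steps bear on it only indirectly. They do show that, among these three compounds, changing this group has moved the number only modestly. No shift beyond the scatter is therefore expected, and the estimated step in this assay is small (a 1.2-fold lower number from compound 3 to compound 4 (0.06 log units; within the scatter)). Compound 4 is expected at about 70 nM (estimated range 25 nM to 200 nM).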

Compound 4, half-maximal inhibitory concentration in the HCT-116 assay: 27 nM
Beside the measured number, compound 4's estimate is 2.6-fold (0.41 log units) above it, within the range that was stated.
By their numbers in the HCT-116 assay, from the lowest: compounds 1, 4 and 2 (each within the scatter of the next); then compound 3.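

In the HCT-116 assay, this position on the carbonyl carbon proves sensitive to ring size within the amine-bearing groups, with 1-aminocyclopentyl in place of 1-aminocyclopropyl giving a step beyond the scatter (a 3.0-fold lower number from compound 3 to compound 4 (0.48 log units; beyond the scatter)). The presence of an amine-bearing ring therefore does not by itself carry the loss seen with compound 3, since in the HCT-116 assay 1-aminocyclopentyl is not separated from methyl (a 1.1-fold higher number from compound 1 to compound 4 (0.05 log units; within the scatter)) or from 2-methoxyethyl (a 1.4-fold lower number from compound 2 to compound 4 (0.15 log units; within the scatter)). In a physicochemical assay for solubility, at pH 7.4 (on this read-out higher numbers stand for higher solubility and lower numbers for lower solubility), the same exchange also separates compound 3 (7 ug/mL) from compound 4 (53 ug/mL), with inhibition and solubility both improving from compound 3 to compound 4: the measured solubility of compound 3, 7 ug/mL, and of compound 4, 53 ug/mL, a 7.6-fold higher number (0.88 log units; beyond the scatter)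

From the compounds shown here alone, what remains open is whether a 1-aminocyclobutyl or 1-aminocyclohexyl group would follow compound 4 or compound 3. Going by these compounds, it is also open whether the amine itself matters, which a plain cyclopentyl or a 1-hydroxycyclopentyl group could show.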